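Methyl for Fluoro on the Benzyl Group of Compound 3

This account rests on a few compounds, and the source may have more. Where it says the series, first, only, none or still open, it means among the compounds named here.

Among the measured compounds shown here, compound 3 `COc1ccc(-c2ccc3c(c2)C(=O)C(=O)N3Cc2ccc(F)cc2)cc1` is the only member of this small set with a measured number: in a functional assay on K562 cells (Homo sapiens) for antiproliferative activity, read by MTT assay, with a stated time of 48 h (on this read-out higher numbers stand for weaker inhibition and lower numbers for stronger inhibition), compound 3 gives 560 nM. Compound 1 `Cc1ccc(-c2ccc3c(c2)C(=O)C(=O)N3)cc1` reaches only the assay limit, > 10000 nM in this assay. Compound 2 `COc1ccc(-c2ccc3c(c2)C(=O)C(=O)N3c2ccc(OC)cc2)cc1` likewise sits at the limit, > 10000 nM. For the measured compounds named here, the step of an at least 17-fold lower number from compound 2 to compound 3 (1.25 log units; beyond the scatter) is the single measured step, and the results at the limit of > 10000 nM in this assay, at which 2 of the 3 values shown sit, leave compound 3 standing alone. Compound 4 `COc1ccc(-c2ccc3c(c2)C(=O)C(=O)N3Cc2ccc(C)cc2)cc1` differs from compound 3 by methyl in place of fluoro on an aromatic carbon. Going by the values given here, no measured step touches this exchange; the one known step concerns the group on the amide-type nitrogen. The change is therefore expected to stay within the scatter, and compound 4 is estimated at 600 nM (range 250 nM to 1400 nM), an expected step of a 1.1-fold higher number from compound 3 to compound 4 (0.03 log units; within the scatter).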

Compound 4, half-maximal inhibitory concentration: 270 nM
Compound 4: the middle estimate sits 2.2-fold (0.35 log units) above what was measured; the measured number falls inside the stated range.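

In this assay, among the compounds shown here, the aromatic carbon para to a large group on the benzyl ring proved responsive, a position no earlier step had touched: methyl in place of fluoro gives a 2.1-fold lower number from compound 3 to compound 4 (0.32 log units; beyond the scatter). The exchange involves one heavy atom for one heavy atom, with no hydrogen-bond donor or acceptor on either side. The change of group on the amide-type nitrogen reads as an at least 37-fold lower number from compound 2 to compound 4 (1.56 log units; beyond the scatter), a bound rather than an exact size, since one end is a limit: the limit of > 10000 nM in this assay, at which 2 of the 4 values shown sit.

As far as these compounds go, whether chloro, an amine or a carboxylic acid at this position would lower the number further remains open. So does the effect of a longer chain in place of methyl.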